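A Bromo-to-Methyl Step at the Weak End

The compounds below may be only part of what the source reports. "The series", "measured", "known", "first", "only" and "open" are said of these compounds alone.

Of the compounds shown here, two have been measured in a functional assay on SK-MEL-2 cells (Homo sapiens) for cytotoxicity; a lower number here means a stronger inhibitor, a higher number a weaker inhibitor. Compound 1 `Cc1ccc(C2CN(S(=O)(=O)c3ccccc3)C(=O)N2)cc1` reads > 316000 nM, which is a limit of the assay and not a number. For the measured compounds named here, compound 2 `O=C1NC(c2ccc(Br)cc2)CN1S(=O)(=O)c1ccc(Cl)cc1` gives 111000 nM, the only true number so far, and no measured step connects it to compound 1.

Compound 3 `Cc1ccc(C2CN(S(=O)(=O)c3ccc(Cl)cc3)C(=O)N2)cc1` departs from compound 2 at one place: methyl in place of bromo on an aromatic carbon. This is methyl in place of bromo on an aromatic carbon, para to a large group. The data hold no direct measure of this change in this assay. A slight shift toward weaker inhibition is expected, since compound 1, which also carries the 4-methylphenyl group, stands at > 316000 nM. The expected size is small, a 1.4-fold higher number from compound 2 to compound 3 (0.16 log units; within the scatter), and may not exceed the usual scatter. Compound 3 is estimated at 160000 nM, with an expected range of 70000 nM to 316000 nM.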

Compound 3, half-maximal inhibitory concentration: 123000 nM
For compound 3 the middle estimate is 1.3-fold (0.11 log units) above the measured one, and the stated range covers the measured number.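

With the chloro group held in place, the change from 4-bromophenyl to 4-methylphenyl now has a direct measure in this assay, a 1.1-fold higher number from compound 2 to compound 3 (0.04 log units; within the scatter), so bromo and methyl cannot be told apart at this position. The second change, chloro in place of hydrogen on an aromatic carbon, gives an at least 2.5-fold lower number from compound 1 to compound 3 (0.40 log units; beyond the scatter), and unlike the first step it lies beyond the scatter. That step is only a bound, since compound 1 stands at a limit of the assay and not at a number: the limit of > 316000 nM in this assay, at which 1 of the 3 values shown sits.

The compounds shown leave open whether an amine, a carboxylic acid or a longer chain at the position of the methyl would move the number at all. They also leave open whether the chloro step would hold with bromo in place of methyl.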